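The source may report more compounds than this note shows. Statements on the series, on what has been measured and on what is new or still open speak of the compounds shown alone.

Measured compounds in an assay (Rattus norvegicus) for inhibition of Fatty-acid amide hydrolase 1 (Homo sapiens); a lower number here means a stronger inhibitor, a higher number a weaker inhibitor:
compound 1 `O=C(CCCCCCc1ccccc1)c1ncc(-c2ccccc2C(=O)C(F)(F)F)o1`, 5000 nM
compound 2 `Nc1cccc(-c2cnc(C(=O)CCCCCCc3ccccc3)o2)c1`, 19 nM
compound 3 `O=C(CCCCCCc1ccccc1)c1ncc(-c2cccc(C(=O)C(F)(F)F)c2)o1`, 16 nM

Compound 2 sits between the other two: its number is well below that of compound 1, whereas compound 3 lies within the scatter of it, so no order between compound 2 and compound 3 can be claimed. Among the compounds with values here, the one measured single-point step, a 1.2-fold lower number from compound 2 to compound 3 (0.07 log units; within the scatter), shows that exchanging the aromatic substituent on the shared core leaves the number essentially unchanged in that case.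

Compound 4 `O=C(O)c1ccc(-c2cnc(C(=O)CCCCCCc3ccccc3)o2)cc1` differs from compound 2 in one place: 4-carboxyphenyl in place of 3-aminophenyl on an aromatic carbon. Within the data shown here, no measured step covers a carboxyl group, nor a change of the substituent's position on the phenyl ring, so the only bearing step is the one from compound 2 to compound 3, which was within the scatter. The exchange here is larger, and a modest weakening is expected; compound 4 is estimated at 100 nM (range 20 nM to 500 nM), a step of a 5.3-fold higher number from compound 2 to compound 4 (0.72 log units; beyond the scatter) expected against compound 2.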

Compound 4, inhibition constant: 60 nM
For compound 4 the middle estimate is 1.7-fold (0.22 log units) above the measured one; measured number inside the range.
By their numbers in this assay, from the lowest: compounds 3 and 2 (each within the scatter of the next); then compound 4; then compound 1.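

In this assay, within the data shown here, a 3.2-fold higher number from compound 2 to compound 4 (0.50 log units; beyond the scatter) is the first step at this position, on the aromatic carbon next to the ring oxygen, to lie beyond the scatter, whereas a 1.2-fold lower number from compound 2 to compound 3 (0.07 log units; within the scatter) stayed within it. The number at this position therefore does respond to the phenyl substituent, although the step is modest and a 4-carboxyphenyl group is accepted here. Nothing measured on these groups accounts for the step.

The step exchanges both the group and its place on the phenyl ring, so the share of each remains unresolved. An unsubstituted phenyl, a methyl ester of the carboxylic acid or a nitrile among the compounds shown would help to separate the two.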